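Same atoms, joined differently: estimating plasma protein binding

The source may report more compounds than this note shows. Statements on the series, on what has been measured and on what is new or still open speak of the compounds shown alone.

Compound 1 `Cc1ccn(-c2ccc(Cn3cc(C(=O)O)c(=O)c4c(F)cccc43)cc2)n1`: 94.3%
Compound 2 `O=C(O)c1cn(Cc2ccc(-n3cnc4ccccc43)cc2)c2cccc(F)c2c1=O`: 91.6%

In an ADME assay on a cell-free system (plasma, Rattus norvegicus) for protein binding, compound 2 gives 91.6%, which lies within the scatter of compound 1. Compound 3 `O=C(O)c1cn(Cc2ccc(-n3ccc4cccnc43)cc2)c2cccc(F)c2c1=O` keeps the rest of compound 2 and alters one group: a group of 9 heavy atoms (7 carbon, 2 nitrogen; one five-membered aromatic ring with 1 hetero atom, one six-membered aromatic ring with 1 hetero atom) in place of a group of 9 heavy atoms (7 carbon, 2 nitrogen; one five-membered aromatic ring with 2 hetero atoms, one six-membered aromatic ring of carbon only), on an aromatic carbon. The two compounds have the same atoms, joined differently. Among the compounds with values here, only one measured step bears on this change: a 1.5-fold higher unbound fraction from compound 1 to compound 2 (0.17 log units; within the scatter). That step also exchanged a group on an aromatic carbon and stayed small, but it was a different exchange, so it is only a rough guide. No step beyond the scatter is therefore expected in this assay, and the data point to no direction. For compound 3 the expected step is a 1.1-fold lower unbound fraction from compound 2 to compound 3 (0.05 log units; within the scatter). Compound 3 is estimated at 92.5%, with an expected range from 87% to 96%.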

Compound 3, plasma protein binding: 99%
Estimate against measurement, compound 3: 7.5-fold (0.88 log units) (unbound fraction) above; the whole stated range lies below it.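

At this position, the exact arrangement of atoms in the fused ring pair matters: moving one nitrogen from the five-membered ring to the six-membered ring leaves the counted atoms, donors and acceptors the same, yet in this assay it gives an 8.4-fold lower unbound fraction from compound 2 to compound 3 (0.92 log units; beyond the scatter). Compound 3 also stands apart from the smaller group, with a 5.7-fold lower unbound fraction from compound 1 to compound 3 (0.76 log units; beyond the scatter), while a 1.5-fold higher unbound fraction from compound 1 to compound 2 (0.17 log units; within the scatter), so across these three compounds, heavy-atom count alone does not set the reading. Nothing at hand explains why this rearrangement lowers the unbound fraction so far.

As far as these compounds go, it remains open whether the effect follows the nitrogen in the six-membered ring, which an indol-1-yl group, with carbon only in that ring, would help to test. An amine on the fused rings could show whether this position tolerates further change.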